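Aniline series: thiophen-2-yl to phenyl on the core

The source may hold more compounds than are shown below. What is called first, only, known or untested is meant among the compounds shown, and "the series" means these compounds.

Measured compounds:
compound 1 `CCc1ccc(-c2nn3cc(-c4cccc(N)c4)nc3s2)cc1`: 6000 nM
compound 2 `C=C(Br)C(=O)Nc1cccc(-c2cn3nc(-c4ccccc4)sc3n2)c1`: 600 nM
compound 3 `Nc1cccc(-c2cn3nc(-c4cccs4)sc3n2)c1`: > 250000 nM

In a functional assay on L1210 cells (Mus musculus) for inhibition, read by cell counting, with a stated time of 2 days (a lower number here means a stronger inhibitor, a higher number a weaker inhibitor), compound 1 gives 6000 nM and compound 2 gives 600 nM. For compound 3 only a limit of the assay is known, > 250000 nM, so compound 3 sits at the limit of > 250000 nM in this assay, at which 1 of the 3 values shown sits, and its true position is open. Compound 4 `Nc1cccc(-c2cn3nc(-c4ccccc4)sc3n2)c1` differs from compound 3 by phenyl in place of thiophen-2-yl on an aromatic carbon. No step between measured compounds is shown, so the size of this change cannot be read from the data; in this assay a move from the limit toward a measurable, stronger value is expected, but it may remain near the limit. Compound 4 is estimated at 80000 nM, within 10000 nM to 300000 nM, which is an expected step of an at least 3.1-fold lower number from compound 3 to compound 4 (0.49 log units; beyond the scatter).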

Compound 4, half-maximal inhibitory concentration: 32000 nM
The estimate for compound 4 lay 2.5-fold (0.40 log units) above the measured number, and the stated range covers the measured number.
By their numbers in this assay, from the lowest: compound 2; then compound 1; then compound 4. At a limit, above all of these: compound 3.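

In this assay, phenyl in place of thiophen-2-yl on the shared core gives an at least 7.8-fold lower number from compound 3 to compound 4 (0.89 log units; beyond the scatter), so the true size of this change is not fixed. Compound 3 is a limit and not a number: the limit of > 250000 nM in this assay, at which 1 of the 4 values shown sits.

Compound 4 also links the series to two other changes: hydrogen in place of (1-bromoethenyl)carbonyl on a nitrogen on an aromatic ring gives a 53-fold higher number from compound 2 to compound 4 (1.73 log units; beyond the scatter), and hydrogen in place of ethyl on an aromatic carbon gives a 5.3-fold higher number from compound 1 to compound 4 (0.73 log units; beyond the scatter).

Open: how furan-2-yl or pyridin-2-yl at this place compares with phenyl, and whether a propyl chain in place of ethyl lowers the number.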